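Dropping one trifluoromethyl from compound 1

The source may report more compounds than this note shows. Statements on the series, on what has been measured and on what is new or still open speak of the compounds shown alone.

Among the measured compounds shown here, in a functional assay on UACC-62 cells (Homo sapiens) for inhibition, read by sulforhodamine B assay, with a stated time of 48 h (on this read-out lower numbers stand for stronger inhibition of growth and higher numbers for weaker inhibition of growth), compound 1 (`COc1cc(-c2nn(-c3cccc(NC(=O)Nc4cc(C(F)(F)F)cc(C(F)(F)F)c4)c3)cc2-c2ccncc2)ccc1Cl`) gives 1580 nM, the lowest of the two numbers so far. Compound 2 (`O=C(Nc1cccc(-n2cc(-c3ccncc3)c(-c3ccc(Cl)c(O)c3)n2)c1)Nc1ccc(Cl)c(Cl)c1`) gives 5210 nM, a gap beyond the scatter. Compound 3 (`COc1cc(-c2nn(-c3cccc(NC(=O)Nc4cccc(C(F)(F)F)c4)c3)cc2-c2ccncc2)ccc1Cl`) carries hydrogen in place of trifluoromethyl on an aromatic carbon and keeps the other trifluoromethyl group. For the measured compounds named here, no measured pair isolates this change, so the expectation is loose. In this assay this change is expected to give an estimated step of a 1.8-fold higher number from compound 1 to compound 3 (0.25 log units; within the scatter), where a higher number means weaker inhibition of growth. For compound 3 the estimated value is 2800 nM with an expected range from 1000 nM to 7000 nM in these notes.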

Compound 3, concentration for total growth inhibition: 1590 nM
For compound 3 the middle estimate is 1.8-fold (0.25 log units) above the measured one; the measured number falls inside the stated range.
By their numbers in this assay, from the lowest: compounds 1 and 3 (each within the scatter of the next); then compound 2.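

Replacing one trifluoromethyl with hydrogen gives a 1.0-fold higher number from compound 1 to compound 3 (0.00 log units; within the scatter) in this assay. Among the compounds shown here, this is the first pair differing in one place, and it shows that, at this aromatic carbon, loss of the second trifluoromethyl group leaves the number within the scatter. No measurement available here accounts for this result.

Whether the position accepts other groups remains open, since an amine or a carboxylic acid at this carbon is not among the compounds shown. Going by these compounds, the effect of removing the remaining trifluoromethyl group also remains open.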